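The source may hold more compounds than are shown below. What is called first, only, known or untested is meant among the compounds shown, and "the series" means these compounds.

Measured compounds in an ADME assay on BCBL1 cells (Homo sapiens) for cytotoxicity, with a stated time of 7 days; on this read-out lower numbers stand for higher toxicity in this test and higher numbers for lower toxicity in this test:
Compound 1 `CCOc1nc(N)nc2c1ncn2/C=C1/CC1(CO)CO` gives > 20000 nM, which is a limit of the assay rather than a number.
Compound 2 `CC(C)Nc1nc(N)nc2c1ncn2/C=C1/CC1(CO)CO` gives > 20000 nM, again a limit and not a number.
Compound 3 `Nc1nc2c(ncn2/C=C2/CC2(CO)CO)c(=O)[nH]1` gives > 20000 nM, also a limit.

Working notes. Compound 2 stands at the upper limit of this assay, and so do the two other values shown; all three sit at the limit of > 20000 nM in this assay, at which 3 of the 3 values shown sit. Within the data shown here, no compound in the set has given a number, so no order among them can be read. Among the measured compounds shown here, the one single-point change among the measured compounds, a step that the two limits leave unreadable from compound 1 to compound 2, is therefore unreadable in size and direction.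

Compound 4 `CCCCCOc1nc(N)nc2c1ncn2/C=C1/CC1(CO)CO` is the next compound. It differs from compound 2 by pentyloxy in place of isopropylamino on an aromatic carbon.

For the measured compounds named here, the only measured step that touches this position is the unreadable one from compound 1 to compound 2, so no step of known size bears on the change to compound 4. With every value shown resting at the limit, the expectation for this assay is that no step beyond the scatter will appear and that the limit will most likely be reported again. The step this estimate means, a step that the limit leaves unreadable from compound 2 to compound 4, is expected to be flat. Compound 4 is accordingly estimated at 30000 nM, with a range from 12000 nM to 100000 nM.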

Compound 4, half-maximal cytotoxic concentration: > 20000 nM
Compound 4 was reported as a limit (the forecaster's own chance of this, stated with the estimate: 80%); the middle value is on the limit's open side.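

Among these compounds, compound 4 gives > 20000 nM in this assay, which is a limit, so no step from compound 1 or compound 2 to compound 4 can be read. Every value shown rests at the same limit: the limit of > 20000 nM in this assay, at which 4 of the 4 values shown sit. The compounds shown leave open whether any change on the shared core would give a number in this assay.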